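Thioether analogue series: pyrazole for isoxazole swap

This account rests on a few compounds, and the source may have more. Where it says the series, first, only, none or still open, it means among the compounds named here.

Compound 1 `Cc1noc(C)c1-c1cnc(N)c(Oc2ccc(C(=O)Nc3ccc(Cl)cc3)cc2)n1` and compound 2 `Cn1cc(-c2cnc(N)c(Oc3ccc(C(=O)Nc4ccc(Cl)cc4)cc3)n2)cn1` share one core; compound 3 `Cc1noc(C)c1-c1cnc(N)c(Sc2ccc(C(=O)Nc3ccc(Cl)cc3)cc2)n1` and compound 4 `Cn1cc(-c2cnc(N)c(Sc3ccc(C(=O)Nc4ccc(Cl)cc4)cc3)n2)cn1` share another, and the difference between the two cores is not broken down here. In a functional assay on U-87MG ATCC cells for inhibition, with U-87 MG (Homo sapiens) as the target, read by MTT assay, with a stated time of 72 h (on this read-out higher numbers stand for weaker inhibition and lower numbers for stronger inhibition), compound 1 gives 15500 nM. In this assay compound 2 gives 35800 nM. The change 1-methyl-1H-pyrazol-4-yl in place of 3,5-dimethyl-1,2-oxazol-4-yl on an aromatic carbon made a 2.3-fold higher number from compound 1 to compound 2 (0.36 log units; beyond the scatter). For compound 3 in this assay the result is a limit of the assay, > 100000 nM; this is the limit of > 100000 nM in this assay, at which 1 of the 3 values shown sits. The change from compound 3 to compound 4 is the same one, (1-methyl-1H-pyrazol-4-yl in place of 3,5-dimethyl-1,2-oxazol-4-yl on an aromatic carbon), at the same place on the ring. Compound 4 has not yet been measured in this assay. For compound 4 in this assay the expected step is a step that the limit leaves unreadable from compound 3 to compound 4, and this expectation rests on compound 1 and compound 2, whose step was a 2.3-fold higher number from compound 1 to compound 2 (0.36 log units; beyond the scatter). Starting from a limit, compound 4 is expected at 230000 nM, within a range from 100000 nM to 600000 nM, and the assay would most likely again report only a limit.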

Compound 4, half-maximal inhibitory concentration: > 100000 nM
Compound 4: only a limit was reported (the forecaster's own chance of this, stated with the estimate: 85%); the middle value lies beyond the limit too.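

Compound 3 and compound 4 both end at a limit in this assay, not at a number, so no step can be read between them: the limit of > 100000 nM in this assay, at which 2 of the 4 values shown sit.

From the compounds shown here alone, whether 1-methyl-1H-pyrazol-4-yl in place of 3,5-dimethyl-1,2-oxazol-4-yl changes the read-out on the core of compound 3, as it did on the core of compound 1, stays open.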